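This account rests on a few compounds, and the source may have more. Where it says the series, first, only, none or still open, it means among the compounds named here.

Working notes on the series in a functional assay (trachea) with Cavia porcellus as the target; on this read-out lower numbers stand for stronger inhibition and higher numbers for weaker inhibition. Compound 1 (`CCCCn1nc(-c2cccnc2)c2ccccc2c1=O`) gives 2290 nM, compound 2 (`O=c1c2ccccc2c(-c2cccnc2)nn1CC1CCCCC1`) gives 209 nM, and compound 3 (`CCOC(=O)CCCn1nc(-c2cccnc2)c2ccccc2c1=O`) gives 10000 nM, the highest number of the three. Next comes compound 4 (`O=C(O)CCCn1nc(-c2cccnc2)c2ccccc2c1=O`), with the change hydrogen in place of ethyl on an oxygen next to a carbonyl group, so that ethoxycarbonyl becomes carboxy.

Going by the values given here, no measured step makes this change. The nearest evidence comes from the chain that carries it. The modest 4.4-fold higher number from compound 1 to compound 3 (0.64 log units; beyond the scatter) and the large 48-fold higher number from compound 2 to compound 3 (1.68 log units; beyond the scatter) both point to higher numbers with ethoxycarbonyl on the chain, and the large 11-fold lower number from compound 1 to compound 2 (1.04 log units; beyond the scatter) shows how far this chain can move the read-out. A small to modest step towards a higher number is therefore expected in this assay, although a step within the scatter remains possible. The estimated step is a 1.4-fold higher number from compound 3 to compound 4 (0.15 log units; within the scatter). For compound 4 the expected value is 14000 nM, with an estimated range of 4000 nM to 50000 nM.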

Compound 4, half-maximal inhibitory concentration: > 100000 nM
Compound 4 ended at the assay's limit; the forecaster's own chance of this, stated with the estimate: 30%; at least 7.1-fold (0.85 log units) between middle value and limit.
By their numbers in this assay, from the lowest: compound 2; then compound 1; then compound 3. At a limit, above all of these: compound 4.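

In this assay compound 4 is read at a limit and not as a number: the limit of > 100000 nM in this assay, at which 1 of the 4 values shown sits. Hydrogen in place of ethyl on an oxygen next to a carbonyl group, so that ethoxycarbonyl becomes carboxy, gives a further rise (an at least 10-fold higher number from compound 3 to compound 4 (1.00 log units; beyond the scatter)), which shows that this end of the chain still moves the read-out once ethoxycarbonyl is already in place. The wider gaps (an at least 43-fold higher number from compound 1 to compound 4 (1.64 log units; beyond the scatter) and an at least 470-fold higher number from compound 2 to compound 4 (2.67 log units; beyond the scatter)) extend the direction seen with compound 3, and carboxy gives the highest reading of the four.

Going by these compounds, the true size of these steps stays open, since all three end at a limit. Also open, on these data alone, is whether a primary amide or an amine at the chain end, or carboxy on a shorter or longer chain, would bring the number back towards that of compound 1.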